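The compounds below may be only part of what the source reports. "The series", "measured", "known", "first", "only" and "open" are said of these compounds alone.

Compound 1 `COC(=O)CN(C)Cc1c(OC)cc(OC)c(C(=O)/C=C/c2ccccc2Cl)c1O` stands second highest of three numbers in a functional assay on A549 cells (Homo sapiens) for antiproliferative activity, with a stated time of 72 h (on this read-out lower numbers stand for stronger inhibition and higher numbers for weaker inhibition), where compound 1 gives 9100 nM. Its nearest neighbour is compound 2 `COc1cc(OC)c(C(=O)/C=C/c2ccccc2Cl)c(O)c1CN1CCCC1`, which in this assay gives 2600 nM, and the furthest is compound 3 `COc1cc(OC)c(C(=O)/C=C/c2ccccc2Cl)c(O)c1CN(C)CC(=O)O`, which gives 79400 nM. Compound 4 `CCN(CC)Cc1c(OC)cc(OC)c(C(=O)/C=C/c2ccccc2Cl)c1O` differs from compound 1 by diethylamino in place of ((methoxycarbonyl)methyl)(methyl)amino on a saturated chain carbon bound to an aromatic carbon. The step that bears most directly on this is a 3.5-fold lower number from compound 1 to compound 2 (0.54 log units; beyond the scatter), a modest gain when a plain cyclic amine took the place of the ester-bearing amine. The steps of an 8.7-fold higher number from compound 1 to compound 3 (0.94 log units; beyond the scatter) and a 31-fold higher number from compound 2 to compound 3 (1.48 log units; beyond the scatter) point the other way, but they involve the free acid, which compound 4 does not carry. Diethylamino, like pyrrolidin-1-yl, brings no carbonyl group. A step of similar size and direction to that of compound 2 is therefore expected, namely a 3.0-fold lower number from compound 1 to compound 4 (0.48 log units; beyond the scatter). Compound 4 is estimated at 3000 nM in this assay, with a range from 1000 nM to 9000 nM.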

Compound 4, half-maximal inhibitory concentration: 3600 nM
Beside the measured number, compound 4's estimate is 1.2-fold (0.08 log units) below it, and the stated range covers the measured number.
By their numbers in this assay, from the lowest: compounds 2 and 4 (each within the scatter of the next); then compound 1; then compound 3.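

In this assay the diethylamino group, which has no ring, gives a 2.5-fold lower number from compound 1 to compound 4 (0.40 log units; beyond the scatter) and also a 22-fold lower number from compound 3 to compound 4 (1.34 log units; beyond the scatter), so at this position the lower number seen with pyrrolidin-1-yl is not confined to a cyclic amine. The step of a 1.4-fold higher number from compound 2 to compound 4 (0.14 log units; within the scatter) lies within the scatter, so these two amines cannot be told apart here. No evidence is available to explain these steps. The compounds shown leave open whether a dimethylamino group or a morpholine ring would match diethylamino and pyrrolidin-1-yl, and whether a primary amide in place of the methyl ester would keep the number of compound 1.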